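A few compounds are considered here, and "the series" means these few. Any claim that something is new, unique, unknown or untested is made for them only; others in the source may bear on it.

Compound 1 `COc1cc(C(=O)c2sc(-c3cccs3)cc2N)cc(OC)c1OC`: 8.9 nM in a functional assay on MOLT-4 cells (Homo sapiens) for antiproliferative activity; a higher number here means a weaker inhibitor, a lower number a stronger inhibitor
Compound 2 `COc1cc(C(=O)c2sc(-c3ccc(F)cc3)cc2N)cc(OC)c1OC`: 12 nM
Compound 3 `COc1cc(C(=O)c2sc(-c3ccc(Cl)c(Cl)c3)cc2N)cc(OC)c1OC`: 270 nM

Three compounds sharing one core were measured. Compound 2 stands second highest of the three numbers; its nearest neighbour is compound 1, a step of a 1.3-fold higher number from compound 1 to compound 2 (0.13 log units; within the scatter) that lies within the scatter, and its furthest is compound 3, a step of a 23-fold higher number from compound 2 to compound 3 (1.35 log units; beyond the scatter) that lies well beyond it. Compound 1 to compound 3 likewise shows a 30-fold higher number from compound 1 to compound 3 (1.48 log units; beyond the scatter).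

The unmeasured compound 4 `COc1cc(C(=O)c2sc(-c3cccc([N+](=O)[O-])c3)cc2N)cc(OC)c1OC` differs from compound 2 in one place: 3-nitrophenyl in place of 4-fluorophenyl on an aromatic carbon.

Among the measured compounds shown here, only the step from compound 2 to compound 3 bears directly on this change, since it also replaces 4-fluorophenyl with a substituted phenyl, and it was large and towards a higher number. For the measured compounds named here, no measured compound carries a 3-nitrophenyl, so the size of its own effect is unknown. On this basis compound 4 is expected to give a higher number than compound 2, by a step estimated at a 5.0-fold higher number from compound 2 to compound 4 (0.70 log units; beyond the scatter), though smaller than the step to compound 3 is taken as the more likely outcome. The estimate for compound 4 in this assay is 60 nM, with a range from 15 nM to 300 nM.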

Compound 4, half-maximal inhibitory concentration: 7.5 nM
Estimate against measurement, compound 4: 8.0-fold (0.90 log units) above, outside the stated range (below it).
By their numbers in this assay, from the lowest: compounds 4, 1 and 2 (each within the scatter of the next); then compound 3.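

In this assay, this position, on the aromatic carbon next to the ring sulfur, accepts a 3-nitrophenyl with no change beyond the scatter against either of the two groups that matched there (a 1.6-fold lower number from compound 2 to compound 4 (0.20 log units; within the scatter); a 1.2-fold lower number from compound 1 to compound 4 (0.07 log units; within the scatter)). The earlier compounds shown here left open whether the large loss seen with compound 3 would extend to other substituted phenyl rings, and compound 4 goes against any such general reading: its 3-nitrophenyl has more heavy atoms than the 4-fluorophenyl it replaces, yet the loss is confined to the 3,4-dichlorophenyl of compound 3 among the four compounds (a 36-fold lower number from compound 3 to compound 4 (1.56 log units; beyond the scatter)). No data are available to explain why these groups behave so differently.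

From the compounds shown here alone, whether the loss in compound 3 follows from one chlorine or from the pair stays open, and a 3-chlorophenyl and a 4-chlorophenyl would separate those cases. It is also unknown whether the tolerance seen with the 3-nitrophenyl extends to a 3-aminophenyl, a 4-nitrophenyl or a phenyl ring carrying a carboxylic acid.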